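Working notes on the step from compound 3 to compound 4

A few compounds are considered here, and "the series" means these few. Any claim that something is new, unique, unknown or untested is made for them only; others in the source may bear on it.

The series is tested in an assay on isolated protein for inhibition of coagulation factor XII (Homo sapiens); a lower number here means a stronger inhibitor, a higher number a weaker inhibitor. Compound 1 `O=C(Oc1ccccc1)c1cc2cc(CCl)ccc2oc1=O` returns only a limit, > 50000 nM. Compound 2 `O=C(Nc1ccccc1)c1cc2ccccc2oc1=O` gives 42000 nM. Compound 3 `Cc1ccc2oc(=O)c(C(=O)NCc3ccccc3)cc2c1` also returns only a limit, > 50000 nM. Compound 3 thus stands at the limit of this assay, as does compound 1, and compound 2 is the single compound shown with a number, close to that same limit (the limit of > 50000 nM in this assay, at which 2 of the 3 values shown sit). Among the compounds with values here, no pair of the measured compounds differs in one place, so no measured step is available for this series.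

Compound 4 `Cc1cccc(NC(=O)c2cc3cc(C)ccc3oc2=O)c1` is not yet measured. It differs from compound 3 by 3-methylphenyl in place of benzyl on an amide-type nitrogen. Within the data shown here, with no measured step to lean on and with every value shown sitting at or near the limit, the step is expected to be a number no higher from compound 3 to compound 4 (the limit leaves the size open), that is, none beyond the scatter. Compound 4 is therefore estimated at 50000 nM, with a range from 20000 nM to 120000 nM, and a limit rather than a number is the more likely outcome.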

Compound 4, half-maximal inhibitory concentration: 10000 nM
Compound 4: the middle estimate sits 5.0-fold (0.70 log units) above what was measured; the whole stated range lies above it.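

In this assay, within the data shown here, 3-methylphenyl in place of benzyl on an amide-type nitrogen gives an at least 5.0-fold lower number from compound 3 to compound 4 (0.69 log units; beyond the scatter), the first measured step, and it shows that this position responds to the choice of group. Benzyl and 3-methylphenyl have the same counts of heavy atoms and rings, and the two compounds have the same atoms, so the step comes from a difference in how those atoms are joined. Compound 3 gives > 50000 nM, which is a limit and not a number.

From the compounds shown here alone, the full size of the step stays open because compound 3 sits at the limit: the limit of > 50000 nM in this assay, at which 2 of the 4 values shown sit. Also open are whether the methyl of 3-methylphenyl contributes to the step, and how an amine, a carboxylic acid or a longer chain in place of 3-methylphenyl on this nitrogen would read.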